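The compounds below may be only part of what the source reports. "The series", "measured", "known", "first", "only" and "open" are said of these compounds alone.

Measured compounds in a functional assay on the whole organism (strain Kunming) for inhibition, with Mus musculus as the target, in the writhing test, with stated times of 1 h and 15 min, at a dose of 200 mg/kg by the oral route; on this read-out lower numbers stand for less inhibition and higher numbers for more inhibition at the one dose given (going by the name of the read-out):

compound 1, `Cc1ccc(N(C)CC2CCC/C(=C\c3ccc(S(C)(=O)=O)cc3)C2=O)cc1` — 84.5%
compound 2, `Cc1cccc(N(C)CC2CCC/C(=C\c3ccc(S(C)(=O)=O)cc3)C2=O)c1` — 72.8%
compound 3, `Cc1ccc(N(C)CC2CCC/C(=C\c3ccccc3)C2(O)c2ccccc2)cc1` — 64.2%

Compound 1 and compound 2 share one core and differ in a single place: 3-methylphenyl in place of 4-methylphenyl on an amine nitrogen. The step this change made is a number 11.7 percentage points lower from compound 1 to compound 2 (beyond the scatter). Compound 3 carries a different core; the difference between the core of compound 1 and the core of compound 3 is not broken down here. In this assay compound 3 gives 64.2%, which sits well under the value of compound 1 but within the scatter of the value of compound 2, so no order between compound 2 and compound 3 is claimed.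

Compound 4, `Cc1cccc(N(C)CC2CCC/C(=C\c3ccccc3)C2(O)c2ccccc2)c1`, has not yet been measured. It stands to compound 3 as compound 2 stands to compound 1: 3-methylphenyl in place of 4-methylphenyl on an amine nitrogen. The place of the change reads the same in both pairs, so this is the same change, now carried out on the core of compound 3. For the measured compounds named here, only one earlier instance exists, and it was made on a different core, so the carry-over is uncertain. The step expected from compound 3 to compound 4 in this assay is a number 10.2 percentage points lower from compound 3 to compound 4 (beyond the scatter), a drop of roughly the size seen in the step of a number 11.7 percentage points lower from compound 1 to compound 2 (beyond the scatter), but with a wider allowance in both directions. Compound 4 is therefore estimated at 54% in this assay, expected to fall between 40% and 68%.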

Compound 4, a percentage reported as inhibition, in the whole organism at one dose (the size of the read-out at that dose, not a potency): 70.6%
For compound 4 the middle estimate is 16.6 percentage points below the measured one; the measured number lies above the stated range.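

In this assay, putting 3-methylphenyl in place of 4-methylphenyl on the amine nitrogen of the core of compound 3 gives a number 6.4 percentage points higher from compound 3 to compound 4 (within the scatter), so this pair carries no order. The change therefore does not transfer as a fixed step in this series, and the two cores give different results: the same change on two cores in this assay, a number 11.7 percentage points lower (beyond the scatter) from compound 1 to compound 2 and a number 6.4 percentage points higher (within the scatter) from compound 3 to compound 4, 18.1 percentage points apart, beyond the scatter of two such steps These notes rest on a single pair per core, and the two cores differ in more than one place, so they do not show which part of the core goes with the different outcome, nor how the change would read on a third core.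

As far as these compounds go, it remains open whether a plain phenyl, a methoxyphenyl or a chlorophenyl on the amine nitrogen would separate from the two methylphenyl groups on either core. Also open, from the compounds shown here alone, is whether an ethyl or a longer chain in place of the methyl on that nitrogen would give a step that holds on both cores.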